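The compounds below may be only part of what the source reports. "The series", "measured", "known", "first", "only" and "open" are said of these compounds alone.

Measured so far:

Compound 1, `Nc1ccccc1/C=C/c1ccc(O)cc1`, in an ADME assay on HEK293 cells (Homo sapiens) for inhibition, read by MTT assay, with a stated time of 2 days (on this read-out higher numbers stand for weaker inhibition and lower numbers for stronger inhibition), compound 1 gives 7 ug/mL.
Compound 2, `Nc1cccc(/C=C/c2ccc(O)cc2)c1`, in this assay compound 2 gives 7 ug/mL.
Compound 3, `COc1ccccc1/C=C/c1ccc(O)cc1`, in this assay compound 3 gives 41 ug/mL.

Compound 4, `COc1cccc(/C=C/c2ccc(O)cc2)c1`, has not yet been measured. Compound 3 differs from compound 1 by one change, (methoxy in place of amino on an aromatic carbon), and this change gave a 5.9-fold higher number from compound 1 to compound 3 (0.77 log units; beyond the scatter). Compound 4 differs from compound 2 by the same kind of change, (methoxy in place of amino on an aromatic carbon); the places differ in that the group in compound 3 sits ortho to a group of 9 heavy atoms, while in compound 4 it sits meta to a group of 9 heavy atoms. The difference between the cores of compound 1 and compound 2 is not broken down here, and their values show no change at the digits printed. Because compound 1 to compound 3 gave a 5.9-fold higher number from compound 1 to compound 3 (0.77 log units; beyond the scatter), a step of similar size, a 5.0-fold higher number from compound 2 to compound 4 (0.70 log units; beyond the scatter), is expected from compound 2 to compound 4. Compound 4 is estimated at 35 ug/mL, expected between 12 ug/mL and 100 ug/mL.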

Compound 4, half-maximal inhibitory concentration: 24 ug/mL
Beside the measured number, compound 4's estimate is 1.5-fold (0.16 log units) above it; the range from low to high includes it.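

Methoxy in place of amino gave a 3.4-fold higher number from compound 2 to compound 4 (0.54 log units; beyond the scatter) in this assay, so on this second core the number again goes up, which means weaker inhibition. Set beside the earlier step, the two results agree as closely as such measurements allow: the same change on two cores in this assay, a 5.9-fold higher number (0.77 log units; beyond the scatter) from compound 1 to compound 3 and a 3.4-fold higher number (0.54 log units; beyond the scatter) from compound 2 to compound 4, 1.7-fold (0.23 log units) apart, within the scatter of two such steps. This shows the change carrying over between these two cores in this one assay, but it does not show that the same would hold on any other core, nor why the number goes up.

The compounds shown leave open whether the shift follows from losing amino or from gaining methoxy. On these data alone, how a dimethylamino or an ethoxy group would read at the same place remains unknown.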